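Aryl swap at the shared core: compound 2 to compound 3

This account rests on a few compounds, and the source may have more. Where it says the series, first, only, none or still open, it means among the compounds named here.

Measured so far in an assay on HL-60 cells for agonist activity at N-formyl peptide receptor 3 (Homo sapiens), read by calcium flux; on this read-out lower numbers stand for an effect already at smaller amounts and higher numbers for an effect only at larger amounts of compound:
compound 1, `COc1cccc(Cc2cc(C3CCCCC3)nn(CC(=O)Nc3ccc(Br)cc3)c2=O)c1`, compound 1 gives > 50000 nM
compound 2, `COc1ccc(Cc2cc(-c3cccs3)nn(CC(=O)Nc3ccc(Br)cc3)c2=O)cc1`, compound 2 gives > 50000 nM

The number for compound 1 is a limit of this assay, not a measured value. The number for compound 2 is likewise a limit and nothing more. For the measured compounds named here, compound 2 therefore stands at the top edge of what this assay can report, together with compound 1, as the limit of > 50000 nM in this assay, at which 2 of the 2 values shown sit, states; no step between the two has been computed, and the two values show only that neither compound reaches a measurable effect in this assay.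

Compound 3 `COc1ccc(Cc2cc(-c3ccc(F)cc3)nn(CC(=O)Nc3ccc(Br)cc3)c2=O)cc1` differs from compound 2 by 4-fluorophenyl in place of thiophen-2-yl on an aromatic carbon. Going by the values given here, no measured step of this kind exists, and both measured values sit at the limit, so for this assay no step beyond the usual scatter is expected; the most likely outcome is again a limit. The step that the limit leaves unreadable from compound 2 to compound 3 is expected to be essentially none. Compound 3 is estimated at 60000 nM, with a range from 15000 nM to 250000 nM.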

Compound 3, half-maximal effective concentration: > 50000 nM
Compound 3: only a limit was reported; the forecaster's own chance of this, stated with the estimate: 85%; the middle value does not contradict the limit.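

In this assay compound 3 gives > 50000 nM, which is a limit of the assay. No step can be read from compound 2 to compound 3, as both sit at the same limit: the limit of > 50000 nM in this assay, at which 3 of the 3 values shown sit.

The compounds shown leave open whether 4-fluorophenyl in place of thiophen-2-yl changes the effect at all, and what on the shared core would give a measurable value.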